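An Azepane in Place of an Amide-Bearing Pyrrolidine

The source may report more compounds than this note shows. Statements on the series, on what has been measured and on what is new or still open speak of the compounds shown alone.

Of the compounds shown here, three sharing one core have been measured in a functional assay on HEK293 cells for activation of melanin-concentrating hormone receptor 1 (Rattus norvegicus), read by inositol phosphate accumulation; on this read-out lower numbers stand for an effect already at smaller amounts and higher numbers for an effect only at larger amounts of compound. Compound 1 `O=C(CCc1ccc(C(F)(F)F)cc1)Nc1ccc2nc(N3CC4CC3CN4)ccc2c1` gives 490 nM. Compound 2 `CC(C)C(=O)NC1CCN(c2ccc3cc(NC(=O)CCc4ccc(C(F)(F)F)cc4)ccc3n2)C1` gives 90 nM, and compound 3 `O=C(CCCCCCCCCCCCc1ccc(C(F)(F)F)cc1)Nc1ccc2nc([N+]34CCC(CC3)CC4)ccc2c1` gives 25 nM. Among these, compound 2 holds the second-lowest number: compound 3 sits a step below it, and compound 1 a larger step above it. Among the measured compounds shown here, the one step between compounds that differ in a single place is a 5.4-fold lower number from compound 1 to compound 2 (0.74 log units; beyond the scatter), and it concerns the same position of the core that is changed here.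

Compound 4 `O=C(CCc1ccc(C(F)(F)F)cc1)Nc1ccc2nc(N3CCCCCC3)ccc2c1` has not yet been measured in this assay. Its difference from compound 2 is azepan-1-yl in place of 3-((isopropylcarbonyl)amino)pyrrolidin-1-yl on an aromatic carbon. The step from compound 1 to compound 2 shows that exchanging the group at this position can move the number well beyond the scatter, but it involved different groups, so it sets only the scale of what may happen, not the direction. For the measured compounds named here, with no closer precedent, a moderate move toward higher numbers is expected, since compound 1 and compound 2 both carried a larger substituent than azepan-1-yl at this site. For compound 4 the expected result in this assay is 200 nM, within 50 nM to 800 nM, which would mean a step of a 2.2-fold higher number from compound 2 to compound 4 (0.35 log units; beyond the scatter).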

Compound 4, half-maximal effective concentration: 1800 nM
Compound 4: the middle estimate sits 9.0-fold (0.95 log units) below what was measured; measured number above the stated range.
By their numbers in this assay, from the lowest: compound 3; then compound 2; then compound 1; then compound 4.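

In this assay, among the compounds shown here, the exchange of 3-((isopropylcarbonyl)amino)pyrrolidin-1-yl for azepan-1-yl brings a 20-fold higher number from compound 2 to compound 4 (1.30 log units; beyond the scatter), the largest step so far at this place next to the ring nitrogen, and it shows that the number here can rise as well as fall with the group chosen. The group of compound 1 and azepan-1-yl have the same count of heavy atoms, yet they differ by a 3.7-fold higher number from compound 1 to compound 4 (0.57 log units; beyond the scatter), so among these compounds that count alone does not fix the number at this position. No measured evidence accompanies these compounds that could account for the size of either step.

The compounds shown leave open whether the higher number of compound 4 goes with losing the isopropylcarbonylamino side chain or with the change from a five-membered to a seven-membered ring, a question that an unsubstituted pyrrolidin-1-yl group and an azepan-1-yl ring carrying that same side chain would separate. Also open, on these data alone, is where a piperidin-1-yl ring, or a pyrrolidine bearing a free primary amine in place of the amide, would fall.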